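Swapping the ester group on a shared core: ketone to tert-butyl ester

The compounds below may be only part of what the source reports. "The series", "measured", "known", "first", "only" and "open" are said of these compounds alone.

Of the compounds shown here, three built on the same core have been measured. In a functional assay for inhibition of nuclear factor NF-kappa-B complex (Homo sapiens) (on this read-out higher numbers stand for weaker inhibition and lower numbers for stronger inhibition), compound 1 `COc1ccc2c(c1)OC(c1cc(OC)c(OC)c(OC)c1)C(C(=O)OCCc1ccccc1)=C2` gives 16200 nM, compound 2 `COC(=O)C1=Cc2ccc(OC)cc2OC1c1cc(OC)c(OC)c(OC)c1` gives 13800 nM, and compound 3 `CCCC(=O)C1=Cc2ccc(OC)cc2OC1c1cc(OC)c(OC)c(OC)c1` gives 11700 nM. Compound 3 has the lowest of the three numbers, yet the steps of a 1.4-fold lower number from compound 1 to compound 3 (0.14 log units; within the scatter) and a 1.2-fold lower number from compound 2 to compound 3 (0.07 log units; within the scatter) both lie within the scatter, so the three are not distinguishable. Compound 4 `COc1ccc2c(c1)OC(c1cc(OC)c(OC)c(OC)c1)C(C(=O)OC(C)(C)C)=C2` differs from compound 3 by tert-butoxy in place of propyl on a carbonyl carbon. The earlier changes at this same carbonyl carbon, a 1.2-fold lower number from compound 2 to compound 3 (0.07 log units; within the scatter) and a 1.4-fold lower number from compound 1 to compound 3 (0.14 log units; within the scatter), moved the number very little, so no shift beyond the scatter is expected here either: the expected step is a 1.1-fold higher number from compound 3 to compound 4 (0.05 log units; within the scatter). Compound 4 is therefore estimated at 13000 nM, with a range from 5000 nM to 35000 nM.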

Compound 4, half-maximal inhibitory concentration: 14100 nM
Beside the measured number, compound 4's estimate is 1.1-fold (0.04 log units) below it; the range from low to high includes it.
By their numbers in this assay, from the lowest: compounds 3, 2, 4 and 1 (each within the scatter of the next).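

At this carbonyl carbon, tert-butoxy in place of propyl gives a 1.2-fold higher number from compound 3 to compound 4 (0.08 log units; within the scatter) in this assay, so an ester here reads the same as the ketone. The tert-butyl ester also matches the other two esters, with a 1.0-fold higher number from compound 2 to compound 4 (0.01 log units; within the scatter) for tert-butyl in place of methyl and a 1.1-fold lower number from compound 1 to compound 4 (0.06 log units; within the scatter) for tert-butyl in place of phenethyl, which leaves all four groups indistinguishable. Nothing available explains this flat result.

As far as these compounds go, all four compounds carry a ketone or an ester here, so whether a carboxylic acid or an amide at this carbon would shift the number beyond the scatter remains open.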